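The compounds below may be only part of what the source reports. "The series", "measured", "known", "first", "only" and "open" are said of these compounds alone.

The measured compounds:

Compound 1, `COc1ccccc1-n1cc(CN2C(=O)C[C@@H]3CC[C@@]2(C)C3(C)C)nn1`: 350 nM
Compound 2, `Cc1ccc(-n2cc(CN3C(=O)C[C@@H]4CC[C@@]3(C)C4(C)C)nn2)cc1`: 400 nM
Compound 3, `CC1(C)[C@H]2CC[C@]1(C)N(Cc1cn(-c3ccccc3)nn1)C(=O)C2`: 70 nM

In a functional assay on A549 cells (Homo sapiens) for inhibition, read by MTT assay, with a stated time of 24 h (a lower number here means a stronger inhibitor, a higher number a weaker inhibitor), compound 3 stands lowest of the three numbers. Both steps toward it are beyond the scatter, a 5.0-fold lower number from compound 1 to compound 3 (0.70 log units; beyond the scatter) and a 5.7-fold lower number from compound 2 to compound 3 (0.76 log units; beyond the scatter), so on these three compounds the bare phenyl on the aromatic nitrogen gives the strongest inhibitor, and either substituent tried on that phenyl weakens it by a modest amount.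

Compound 4, `CC1(C)[C@H]2CC[C@]1(C)N(Cc1cn(-c3ccccc3Br)nn1)C(=O)C2`, has not yet been measured. It differs from compound 3 in one place: bromo in place of hydrogen on an aromatic carbon

For the measured compounds named here, the step that bears most directly on this is the one from compound 1 to compound 3, in which the 2-methoxyphenyl loses its substituent and the number drops by a modest margin; compound 4 puts a substituent of comparable size back in the same kind of position. The step from compound 2 to compound 3 points the same way with a different group in a different place. Nothing here shows a substituent on this phenyl improving the number. Compound 4 is therefore expected to give about 250 nM in this assay, with a range of 80 nM to 800 nM. That estimate means a 3.6-fold higher number from compound 3 to compound 4 (0.55 log units; beyond the scatter), a weakening of about the size seen before.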

Compound 4, half-maximal inhibitory concentration: 130 nM
Estimate against measurement, compound 4: 1.9-fold (0.28 log units) above, within the range that was stated.
By their numbers in this assay, from the lowest: compounds 3 and 4 (each within the scatter of the next); then compounds 1 and 2 (each within the scatter of the next).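

In this assay, the opening compounds suggested that any substituent on this phenyl weakens inhibition, but bromo ortho to a large group does not fit that reading: a 1.9-fold higher number from compound 3 to compound 4 (0.27 log units; within the scatter), so the 2-bromophenyl and the bare phenyl cannot be told apart here. The change of group at this kind of carbon does register, with a 2.7-fold lower number from compound 1 to compound 4 (0.43 log units; beyond the scatter) for bromo in place of methoxy, and a 3.1-fold lower number from compound 2 to compound 4 (0.49 log units; beyond the scatter) for 2-bromophenyl in place of 4-methylphenyl, so the outcome depends on which group is present and, for the 4-methylphenyl comparison, possibly on where it sits, and compounds 1 and 2 remain the ones that go against a substituent being tolerated. Nothing available explains why bromo and methoxy part ways on this ring.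

The compounds shown leave open whether an amine, a carboxylic acid or a chloro group on this same carbon would stay level with the bare phenyl, as bromo does, or fall back toward the 2-methoxyphenyl. They also leave open whether bromo would hold this standing on another carbon of the ring, and whether the pattern extends beyond this assay.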